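The source may hold more compounds than are shown below. What is called first, only, known or untested is meant among the compounds shown, and "the series" means these compounds.

Compound 1 `C=C(C)CN(CC)Cc1c(C(F)(F)F)nc2n(-c3c(C)cc(C)cc3C)c(Cl)cn12`, compound 2 `CCN(CCC1CC1)Cc1c(C(F)(F)F)nc2n(-c3c(C)cc(C)cc3C)c(Cl)cn12` and compound 3 `Cc1cc(C)c(-n2c(Cl)cn3c(CN4CCCCC4)c(C(F)(F)F)nc23)c(C)c1` share one core and differ only in the amine carried on the saturated chain carbon bound to the aromatic carbon. In an assay on cells for displacement of a labelled ligand from corticotropin-releasing factor receptor 1 (Homo sapiens), with a stated time of 100 min (on this read-out lower numbers stand for stronger inhibition and higher numbers for weaker inhibition), compound 1 gives 67 nM. Compound 2 gives 13 nM in this assay. Compound 3 gives 1200 nM, the highest number of the three. The steps of an 18-fold higher number from compound 1 to compound 3 (1.25 log units; beyond the scatter) and a 92-fold higher number from compound 2 to compound 3 (1.97 log units; beyond the scatter) place the piperidin-1-yl compound far behind both acyclic amines, while a 5.2-fold lower number from compound 1 to compound 2 (0.71 log units; beyond the scatter) between the two acyclic amines is modest. Compound 4 `Cc1cc(C)c(-n2c(Cl)cn3c(CN4CCCC(C)C4)c(C(F)(F)F)nc23)c(C)c1` keeps the piperidin-1-yl group of compound 3 and alters it by methyl in place of hydrogen on a saturated ring carbon. For the measured compounds named here, no measured step adds a methyl to a ring carbon; every measured step replaces the whole amine, so the guidance is indirect. With compound 3 standing so far behind, the expected direction is toward a lower number, yet the step is expected to stay small. The estimated step is a 2.0-fold lower number from compound 3 to compound 4 (0.30 log units; within the scatter). Compound 4 is expected to give about 600 nM, within a range from 200 nM to 1800 nM.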

Compound 4, inhibition constant: 5800 nM
Compound 4: the middle estimate sits 9.7-fold (0.99 log units) below what was measured, and the stated range ends below it.
By their numbers in this assay, from the lowest: compound 2; then compound 1; then compound 3; then compound 4.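

Methyl in place of hydrogen on a saturated ring carbon, two ring bonds from the ring nitrogen, raises the number in this assay, with a 4.8-fold higher number from compound 3 to compound 4 (0.68 log units; beyond the scatter); this is the first step shown that alters the amine without replacing it whole, and it shows that even this single added carbon changes binding beyond the scatter. The distance from the acyclic amines grows as well, with an 87-fold higher number from compound 1 to compound 4 (1.94 log units; beyond the scatter) and a 450-fold higher number from compound 2 to compound 4 (2.65 log units; beyond the scatter), so 3-methylpiperidin-1-yl falls further behind both than piperidin-1-yl does. Nothing available accounts for the rise.

The compounds shown leave open whether an ethyl or a hydroxyl group on the same ring carbon would follow the methyl. They also leave open how a methyl on a carbon of the acyclic amines would fare.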